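Selenium group to 2-aminoethoxy: working notes

The source may report more compounds than this note shows. Statements on the series, on what has been measured and on what is new or still open speak of the compounds shown alone.

Compound 1 `COc1ccc(N(C)c2nc(C)nc3ccccc23)cc1OCCC[Se]C#N`: 852 nM
Compound 2 `COc1ccc(N(C)c2nc(C)nc3ccccc23)cc1C[Se]C#N`: 113 nM

Both values come from a functional assay on HCT-116 cells (Homo sapiens) for inhibition, read by MTT assay, with a stated time of 48 h; on this read-out higher numbers stand for weaker inhibition and lower numbers for stronger inhibition. Compound 2 holds the lower of the two numbers, and the gap to compound 1 lies beyond the scatter. The next entry is compound 3 `COc1ccc(N(C)c2nc(C)nc3ccccc23)cc1OCCN`, and its difference from compound 2 is a group of 4 heavy atoms (2 carbon, 1 nitrogen, 1 oxygen; no ring) in place of a group of 4 heavy atoms (2 carbon, 1 nitrogen, 1 selenium; no ring), on an aromatic carbon. Among the compounds with values here, one measured step bears on this change: a 7.5-fold lower number from compound 1 to compound 2 (0.88 log units; beyond the scatter), modest and beyond the scatter. Within the data shown here, its bearing is only indirect, as it exchanges one selenium-containing group for another, and no measured compound lacks selenium. Compound 3 does keep an oxygen on the aromatic carbon, as does compound 1 at 852 nM. A step of similar size toward a higher number is therefore expected, namely a 5.3-fold higher number from compound 2 to compound 3 (0.73 log units; beyond the scatter) in this assay. For compound 3 the estimated value is 600 nM, with an expected range from 100 nM to 3500 nM.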

Compound 3, half-maximal inhibitory concentration: 198 nM
For compound 3 the middle estimate is 3.0-fold (0.48 log units) above the measured one; measured number inside the range.
By their numbers in this assay, from the lowest: compounds 2 and 3 (each within the scatter of the next); then compound 1.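

In this assay, the change to 2-aminoethoxy on this aromatic carbon gives a 1.8-fold higher number from compound 2 to compound 3 (0.24 log units; within the scatter), so among these compounds selenium is not needed at this position to keep the number in this range. An oxygen on the aromatic carbon also does not by itself go with the higher number, as the chain-end change of one nitrogen atom in place of the selenium-containing group of 4 heavy atoms gives a 4.3-fold lower number from compound 1 to compound 3 (0.63 log units; beyond the scatter). No measured evidence accounts for either step.

From the compounds shown here alone, it remains open whether the amine at the chain end is what matters here, which a hydroxyl group or a dimethylamine at that end could test. A longer aminoalkoxy chain or an aminomethyl group on the same aromatic carbon could show how much the length and the oxygen link contribute.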